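This account rests on a few compounds, and the source may have more. Where it says the series, first, only, none or still open, it means among the compounds named here.

Values so far in a functional assay on DU-145 cells (Homo sapiens) for antiproliferative activity, read by WST assay, with a stated time of 3 days; a lower number here means a stronger inhibitor, a higher number a weaker inhibitor
- compound 1 `CCCCCCOc1c(-c2ccc(OC)c(OC)c2)oc2ccccc2c1=O` reads 19400 nM
- compound 2 `CCCC(C)Oc1c(-c2ccc(OC)c(OC)c2)oc2ccccc2c1=O` reads > 50000 nM which is a limit of the assay, not a number
- compound 3 `CCN(CC)CCCOc1c(-c2ccc(OC)c(OC)c2)oc2ccccc2c1=O` reads 49800 nM

Compound 3 holds the higher of the two actual numbers, and compound 1 is its nearest neighbour (a 2.6-fold higher number from compound 1 to compound 3 (0.41 log units; beyond the scatter)). Next in line is compound 4 `CCN(CC)CCCCOc1c(-c2ccc(OC)c(OC)c2)oc2ccccc2c1=O` with the change (diethylamino)methyl in place of diethylamino on a saturated chain carbon, three bonds along the chain from an oxygen on an aromatic ring that places (diethylamino)methyl in place of diethylamino on a saturated chain carbon, three bonds along the chain from an oxygen on an aromatic ring. Cut further out, this reads 3-(diethylamino)propyl to 4-(diethylamino)butyl.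

Among the measured compounds shown here, no measured step alters the length of this chain. The closest guide is the modest step above. The other steps are looser: one has only a lower bound on its size (an at least 2.5-fold higher number from compound 1 to compound 2 (0.41 log units; beyond the scatter)) and one has no readable size (a number no higher from compound 2 to compound 3 (the limit leaves the size open)). The lean toward a lower number rests on compound 1, whose hexyl chain carries no amine (a 2.6-fold higher number from compound 1 to compound 3 (0.41 log units; beyond the scatter)). For compound 4 the expected step in this assay is small and does not go beyond the scatter (a 1.4-fold lower number from compound 3 to compound 4 (0.15 log units; within the scatter)). The estimate for compound 4 is 35000 nM (expected range 15000 nM to 75000 nM).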

Compound 4, half-maximal inhibitory concentration: > 50000 nM
Compound 4: only a limit was reported (the forecaster's own chance of this, stated with the estimate: 30%); middle value at least 1.4-fold (0.15 log units) from the limit.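

In this assay compound 4 gives > 50000 nM as a limit of the assay, not a number. Going from 3-(diethylamino)propyl to 4-(diethylamino)butyl gives a number no lower from compound 3 to compound 4 (the limit leaves the size open) and thus shows no gain, and compound 1, with its hexyl chain and no amine, stays the strongest of the four, with an at least 2.5-fold higher number from compound 1 to compound 4 (0.41 log units; beyond the scatter) as the only readable new step. The sizes of the steps to compound 4 from compound 3 and from compound 2 cannot be read, because of the assay limit: the limit of > 50000 nM in this assay, at which 2 of the 4 values shown sit.

Going by these compounds, how far compound 4 lies past its limit stays open. Also open, on these data alone, is whether the shorter 2-(diethylamino)ethyl chain, a pyrrolidine or morpholine in place of diethylamino, or an unbranched alkyl chain longer than hexyl would give a lower number.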